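The source may report more compounds than this note shows. Statements on the series, on what has been measured and on what is new or still open speak of the compounds shown alone.

In a physicochemical assay for lipophilicity, read by HPLC, at pH 7.5 (on this read-out lower numbers stand for lower lipophilicity and higher numbers for higher lipophilicity), the three measured compounds read as follows:

- compound 1 `CC[C@@H](Nc1c(C#N)c(-c2ccc(-c3ncccc3C)cc2)nc2cnccc12)C(N)=O` gives 2
- compound 2 `CC[C@@H](Nc1c(C#N)c(-c2ccc(-c3cccc(C)c3F)cc2)nc2cnccc12)C(N)=O` gives 3
- compound 3 `CC[C@@H](Nc1c(C#N)c(-c2ccc(-c3ccccc3N(C)C)cc2)nc2cnccc12)C(N)=O` gives 3.2

These compounds share one core and differ in a single group. Compound 3 sits level with compound 2: the gap is a number 0.20 log units higher from compound 2 to compound 3 (within the scatter) and so does not separate the pair. Compound 3 stands clear of the remaining compound, with a number 1.20 log units higher from compound 1 to compound 3 (beyond the scatter) as the step that shows it.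

The next compound, compound 4 (`CC[C@@H](Nc1c(C#N)c(-c2ccc(-c3cccnc3C)cc2)nc2cnccc12)C(N)=O`), changes that one group, on an aromatic carbon para to a large group: 2-methylpyridin-3-yl in place of 2-(dimethylamino)phenyl on an aromatic carbon (the change in full).

The closest guide is compound 1 (2), whose 3-methylpyridin-2-yl is also a methylpyridinyl group. Two measured steps start from that group and replace it with a ring of carbon only: a number 1.00 log units higher from compound 1 to compound 2 (beyond the scatter) and a number 1.20 log units higher from compound 1 to compound 3 (beyond the scatter) (the second of the two). Both ended higher. Compound 4 goes the opposite way, from a ring of carbon only to a ring with a hetero atom, so a fall of similar size is expected in this assay here. The expected step, an estimate lying beyond the scatter, is a number 1.10 log units lower from compound 3 to compound 4 (beyond the scatter) (lower, not higher). Going by the values given here, no measured compound shows how much the difference between the two methylpyridinyl groups matters, so the range stays fairly wide. The estimate for compound 4 is 2.1 (expected range 1.6 to 2.6).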

Compound 4, distribution coefficient: 1.9
The estimate for compound 4 lay 0.20 log units above the measured number, within the range that was stated.
By their numbers in this assay, from the lowest: compounds 4 and 1 (each within the scatter of the next); then compounds 2 and 3 (each within the scatter of the next).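

Compound 4 gives the direct reverse of the earlier rises, with a ring carrying a hetero atom replacing a ring of carbon only in two separate steps in this assay (a number 1.30 log units lower from compound 3 to compound 4 (beyond the scatter); a number 1.10 log units lower from compound 2 to compound 4 (beyond the scatter)). Going by these compounds alone, it also adds what the earlier compounds could not show: 2-methylpyridin-3-yl and 3-methylpyridin-2-yl, the two methylpyridinyl groups, are not separated at this position (a number 0.10 log units lower from compound 1 to compound 4 (within the scatter)), so across these four compounds, with none going against it, the rings with a hetero atom stand apart from the rings of carbon only, while the two groups within each kind stay level. Nothing here accounts for this split, as no supporting measurement comes with these numbers.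

From the compounds shown here alone, it remains open whether a pyridinyl group without the methyl, or a pyrimidinyl ring, would read level with compound 1 and compound 4, which would show whether the methyl matters at this place. Also open, going by these compounds, is where an aminomethyl group or a carboxylic acid on the same ring would fall, and whether the same swaps give steps of this size on a different core.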